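Working notes: replacing 4-vinylphenyl in compound 3

The source may report more compounds than this note shows. Statements on the series, on what has been measured and on what is new or still open speak of the compounds shown alone.

Measured so far in a functional assay on B16-F0 cells (Mus musculus) for inhibition, read by CCK-8 assay, with a stated time of 48 h; on this read-out lower numbers stand for stronger inhibition and higher numbers for weaker inhibition:
- compound 1 `COc1cc(-c2ccnc3cc(-c4c[nH]c5ccccc45)nn23)cc(OC)c1OC` gives 40 nM
- compound 2 `COc1cc(-c2ccnc3cc(-c4ccc(C)cc4)nn23)cc(OC)c1OC` gives 21 nM
- compound 3 `C=Cc1ccc(-c2cc3nccc(-c4cc(OC)c(OC)c(OC)c4)n3n2)cc1` gives 788 nM

Compound 3 carries the highest number of the three, and its steps to both others lie beyond the scatter. The next analogue is compound 4 `COc1cc(-c2ccnc3cc(-c4cccc(C)c4)nn23)cc(OC)c1OC`, with this change: 3-methylphenyl in place of 4-vinylphenyl on an aromatic carbon, in words 3-methylphenyl in place of 4-vinylphenyl on an aromatic carbon.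

Going by the values given here, two measured steps bear most directly on this. The closest is a 38-fold higher number from compound 2 to compound 3 (1.57 log units; beyond the scatter), where vinyl replaces methyl on the para-free wording of the same aryl group. The other is a 20-fold higher number from compound 1 to compound 3 (1.29 log units; beyond the scatter), and it also ends at the 4-vinylphenyl compound. By contrast, a 1.9-fold lower number from compound 1 to compound 2 (0.28 log units; within the scatter) stays within the scatter. Compound 4 lacks the vinyl group, as do compound 1 and compound 2, so a large step toward a lower number is expected in this assay. Among the compounds with values here, no measured pair shows what moving the methyl does, which widens the range and argues for a somewhat smaller step than the one from compound 3 back to compound 2.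

The step expected is a 13-fold lower number from compound 3 to compound 4 (1.12 log units; beyond the scatter) as an estimate. For compound 4 the estimated value is 60 nM, with an expected range from 15 nM to 300 nM as its limits of expectation.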

Compound 4, half-maximal inhibitory concentration: 2220 nM
The estimate for compound 4 lay 37-fold (1.57 log units) below the measured number; the whole stated range lies below it.
By their numbers in this assay, from the lowest: compounds 2 and 1 (each within the scatter of the next); then compound 3; then compound 4.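

In this assay the outcome at this place on the five-membered aromatic ring depends on more than the loss of the vinyl group: exchanging 4-methylphenyl for 3-methylphenyl alone gives the largest change in the series (a 110-fold higher number from compound 2 to compound 4 (2.02 log units; beyond the scatter)). Removing the vinyl group therefore does not by itself bring the number down, as the step from 4-vinylphenyl to 3-methylphenyl still goes upward (a 2.8-fold higher number from compound 3 to compound 4 (0.45 log units; beyond the scatter)), and compound 4 also stands well apart from the indole-bearing compound (a 56-fold higher number from compound 1 to compound 4 (1.74 log units; beyond the scatter)), so compound 4 now has the highest number of the four, with its steps to all others beyond the scatter. Nothing available offers an explanation for this sensitivity to the arrangement of the aryl group.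

As far as these compounds go, it remains open whether plain phenyl would sit nearer to compound 2 or to compound 4, which would show whether 4-methylphenyl lowers the number or 3-methylphenyl and 4-vinylphenyl raise it. Also open, from the compounds shown here alone, is how the aryl group would respond to a polar substituent such as an amine or a carboxylic acid, or to a longer chain such as 4-ethylphenyl.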